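The compounds below may be only part of what the source reports. "The series", "measured", "known", "first", "only" and "open" are said of these compounds alone.

In an ADME assay on L929 cells (Mus musculus) for cytotoxicity, read by resazurin assay, with a stated time of 72 h (on this read-out higher numbers stand for weaker inhibition and lower numbers for stronger inhibition), the measured compounds read as follows.

Compound 1 `O=C(/C=C/c1ccc2c(c1)B(O)OC2)c1ccccn1` gives > 10 ug/mL (a limit)
Compound 2 `O=C(/C=C/c1ccc2c(c1)B(O)OC2)c1ccco1` gives > 10 ug/mL (a limit)
Compound 3 `O=C(/C=C/c1ccc2c(c1)B(O)OC2)c1ccc(F)cc1` gives > 10 ug/mL (a limit)

In this assay compound 3 stands at > 10 ug/mL as a limit and not as a number. It shares this position with the other two compounds (the limit of > 10 ug/mL in this assay, at which 3 of the 3 values shown sit). The change to compound 4 (`O=C(/C=C/c1ccc2c(c1)B(O)OC2)c1cccs1`) is thiophen-2-yl in place of 4-fluorophenyl on a carbonyl carbon. Three measured exchanges on that carbonyl carbon bear on it: a step that the two limits leave unreadable from compound 1 to compound 2 and a step that the two limits leave unreadable from compound 1 to compound 3 and a step that the two limits leave unreadable from compound 2 to compound 3 in turn. None of them has a readable size, and none has brought a compound off the limit. In this assay no step beyond the scatter is therefore expected, in either direction. The expected size is estimated as a step that the limit leaves unreadable from compound 3 to compound 4 here. That expectation rests on compound 2, with furan-2-yl on the same carbon, which gives > 10 ug/mL as a limit. For compound 4 the estimated value is 15 ug/mL with an expected range from 6 ug/mL to 30 ug/mL and a report as a limit remains likely.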

Compound 4, half-maximal inhibitory concentration: > 10 ug/mL
Compound 4 ended at the assay's limit (the forecaster's own chance of this, stated with the estimate: 80%); the middle value does not contradict the limit.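

In this assay compound 4 gives > 10 ug/mL, which is a limit, so the steps to it from compound 1, compound 2 and compound 3 cannot be read: the limit of > 10 ug/mL in this assay, at which 4 of the 4 values shown sit.

The compounds shown leave open at what concentration any of them would inhibit these cells, and whether the group on the carbonyl carbon alters that concentration.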